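The source may hold more compounds than are shown below. What is called first, only, known or untested is meant among the compounds shown, and "the series" means these compounds.

Within the data shown here, compound 2 `COc1ccc(NC(=O)c2cn(-c3ccccc3)nc2-c2ccccc2)cc1` holds the lowest of the two numbers so far in a functional assay on HCT-116 cells (Homo sapiens) for cytotoxicity, read by MTT assay, with a stated time of 48 h (on this read-out lower numbers stand for stronger inhibition and higher numbers for weaker inhibition), with compound 2 at 1350 nM; compound 1 `O=C(Nc1ccc(Br)cc1)c1cn(-c2ccccc2)nc1-c1ccccc1` gives 4470 nM, and the step of a 3.3-fold lower number from compound 1 to compound 2 (0.52 log units; beyond the scatter) is the only one in hand. Compound 3 `COc1ccc(NC(=O)c2cn(-c3ccccc3)nc2-c2ccc(Cl)cc2)cc1` differs from compound 2 by chloro in place of hydrogen on an aromatic carbon, para to a large group, reading phenyl to 4-chlorophenyl. Among the measured compounds shown here, no measured step touches that ring; the one step recorded concerns the ring bearing the methoxy group, so nothing can be read across. Compound 3 is therefore expected to sit close to compound 2, with a 1.2-fold lower number from compound 2 to compound 3 (0.09 log units; within the scatter) not beyond the scatter. The estimate for compound 3 is 1100 nM, between 400 nM and 3500 nM.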

Compound 3, half-maximal inhibitory concentration: 1330 nM
Compound 3: the middle estimate sits 1.2-fold (0.08 log units) below what was measured; the measured number falls inside the stated range.
By their numbers in this assay, from the lowest: compounds 3 and 2 (each within the scatter of the next); then compound 1.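

Phenyl to 4-chlorophenyl gives the first reading on this ring, and the step (  a 1.0-fold lower number from compound 2 to compound 3 (0.01 log units; within the scatter)) lies within the scatter. Chloro is therefore tolerated here, para to a large group, at least with methoxy on the other ring, whereas the earlier step showed only that the other ring's substituent can move the number. No measurement in hand bears on what lies behind this result. Still open, going by these compounds, is whether an amine or a carboxylic acid at this place would shift the number beyond the scatter. Also open, on these data alone, is whether chloro would behave the same with bromo on the other ring.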